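Methoxy on the anilino ring of a thiazole amide

The source may report more compounds than this note shows. Statements on the series, on what has been measured and on what is new or still open speak of the compounds shown alone.

Of the compounds shown here, two with a shared core have been tested in a functional assay on A498 cells (Homo sapiens) for antiproliferative activity, read by sulforhodamine B assay, with a stated time of 48 h; on this read-out higher numbers stand for weaker inhibition of growth and lower numbers for stronger inhibition of growth. Compound 1 `Cc1nc(SCC(=O)Nc2nc(-c3ccc(Cl)cc3)cs2)n(Nc2ccccc2)c1C` gives 2240 nM, the lowest of the two numbers. Compound 2 `Cc1ccc(Nn2c(SCC(=O)Nc3nc(-c4ccccc4)cs3)nc(C)c2C)cc1` differs from compound 1 in two places at once; in this assay compound 2 gives 17400 nM, a clearly weaker result, and since the two structures differ in more than one place, the comparison tells nothing about either change alone.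

Compound 3 `COc1ccc(Nn2c(SCC(=O)Nc3nc(-c4ccc(Cl)cc4)cs3)nc(C)c2C)cc1` is compound 1 with one alteration: methoxy in place of hydrogen on an aromatic carbon, on an aromatic carbon of a six-membered aromatic ring of carbon only, para to a large group. Within the data shown here, no measured pair shows this change on its own, so the direction must be guessed. The only related case, compound 2, carries a substituent on the same ring and is weaker, but it also lacks the chlorine of compound 1. A small loss is expected, from compound 1 to compound 3 a 1.6-fold higher number from compound 1 to compound 3 (0.19 log units; within the scatter). Compound 3 is therefore estimated at 3500 nM, with a range from 1500 nM to 12000 nM.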

Compound 3, concentration for 50% growth inhibition: 2220 nM
The estimate for compound 3 lay 1.6-fold (0.20 log units) above the measured number; the measured number falls inside the stated range.
By their numbers in this assay, from the lowest: compounds 3 and 1 (each within the scatter of the next); then compound 2.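

In this assay, adding methoxy gives a 1.0-fold lower number from compound 1 to compound 3 (0.00 log units; within the scatter), so this change at this ring carbon, para to a large group, has no effect that can be told apart from the scatter. Among these compounds, this is the only comparison here that isolates a single change on this ring, and it shows that the core of compound 1 can carry the phenyl to 4-methoxyphenyl change without a detectable loss of growth inhibition. No measured evidence is available to explain this result.

On these data alone, whether an amine, a carboxylic acid or a longer alkoxy chain at the same carbon would also leave the number within the scatter remains open. The weaker result for compound 2 also remains unexplained, as its two differences from compound 1 have not been separated.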